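This account rests on a few compounds, and the source may have more. Where it says the series, first, only, none or still open, it means among the compounds named here.

Of the compounds shown here, three have been measured in a functional assay on LNCaP cells (Homo sapiens) for cytotoxicity, read by MTT assay, with a stated time of 72 h; on this read-out higher numbers stand for weaker inhibition and lower numbers for stronger inhibition: compound 1 `CC1=C(/C=C/C(=O)/C=C/c2cccc([N+](=O)[O-])c2)C(C)(C)CCC1` gives 2700 nM, compound 2 `CC1=C(/C=C/C(=O)/C=C/c2cccc(C)c2)C(C)(C)CCC1` gives 17800 nM, and compound 3 `CC1=CCCC(C)(C)C1/C=C/C(=O)/C=C/c1cccc([N+](=O)[O-])c1` gives 3300 nM.

Compound 1 and compound 3 are built from the same atoms joined differently, and the difference between their two cores is not broken down here. Their two values in this assay sit within the usual scatter of each other, so nothing can be said about an order between them.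

Compound 4 `CC1=CCCC(C)(C)C1/C=C/C(=O)/C=C/c1cccc(C)c1` is still to be measured. It differs from compound 3 by methyl in place of nitro on an aromatic carbon. The same change has already been made once, from compound 1 to compound 2, where it reads methyl in place of nitro on an aromatic carbon and where the place is described in exactly the same words, so it counts as the same change. That step was a 6.6-fold higher number from compound 1 to compound 2 (0.82 log units; beyond the scatter).

If the change repeats on the core of compound 3, a step of about a 6.1-fold higher number from compound 3 to compound 4 (0.78 log units; beyond the scatter) is expected, resting on a 6.6-fold higher number from compound 1 to compound 2 (0.82 log units; beyond the scatter) and on the value of compound 3, 3300 nM. For compound 4 the estimate is 20000 nM, expected to fall between 8000 nM and 50000 nM.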

Compound 4, half-maximal inhibitory concentration: 12200 nM
For compound 4 the middle estimate is 1.6-fold (0.21 log units) above the measured one; the measured number falls inside the stated range.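

On the second core, the swap of nitro for methyl again moves the number up in this assay, with a 3.7-fold higher number from compound 3 to compound 4 (0.57 log units; beyond the scatter), which means weaker inhibition just as on the first core. Set side by side, the two steps agree in direction and cannot be told apart in size: the same change on two cores in this assay, a 6.6-fold higher number (0.82 log units; beyond the scatter) from compound 1 to compound 2 and a 3.7-fold higher number (0.57 log units; beyond the scatter) from compound 3 to compound 4, 1.8-fold (0.25 log units) apart, within the scatter of two such steps

So for these two cores, the effect of this change on one core was a fair guide to its effect on the other, but two pairs are a small base and show nothing about any further core or about why the methyl compounds read weaker.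

The compounds shown leave open how an amine, a carboxylic acid or a chlorine atom would read in place of nitro or methyl on the aromatic ring. They also leave open whether the same change would give a similar step on other cell types.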